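Swapping the Furan Amide Tail for an Indazole

The compounds below may be only part of what the source reports. "The series", "measured", "known", "first", "only" and "open" are said of these compounds alone.

Measured so far in an ADME assay on MT4 cells (Homo sapiens) for cytotoxicity, read by MTT assay; a higher number here means that more compound is tolerated, a lower number that less compound is tolerated:
Compound 1 `Cc1cc(C)cc(S(=O)(=O)c2c(C(=O)NC(C)C(=O)NC(C)c3ccncc3)[nH]c3ccc(Cl)cc23)c1` gives 21900 nM.
Compound 2 `Cc1cc(C)cc(S(=O)(=O)c2c(C(=O)NCC(=O)NCc3ccco3)[nH]c3ccc(Cl)cc23)c1` reaches only > 50000 nM, which is a limit of this assay and not a number.

Compound 2 thus stands at the limit of > 50000 nM in this assay, at which 1 of the 2 values shown sits, the best-tolerated end of the values shown. Compound 3 `Cc1cc(C)cc(S(=O)(=O)c2c(C(=O)NCc3n[nH]c4ccccc34)[nH]c3ccc(Cl)cc23)c1` differs from compound 2 by 1H-indazol-3-yl in place of ((furan-2-yl)methyl)carbamoyl on a saturated chain carbon bound to an amide-type nitrogen. For the measured compounds named here, no step between measured compounds is known here, so the direction of this change in this assay is open; a step no larger than the usual scatter is expected, and compound 3 may again land at the limit. The expected step is an at least 1.4-fold lower number from compound 2 to compound 3 (0.15 log units; that floor lies within the scatter). Compound 3 is expected to give 35000 nM, between 12000 nM and 100000 nM.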

Compound 3, half-maximal cytotoxic concentration: > 50700 nM
Compound 3 gave a limit, no number; the forecaster's own chance of this, stated with the estimate: 40%; middle value at least 1.4-fold (0.16 log units) from the limit.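

Compound 2 and compound 3 each gave only a limit of the assay, not a number, so no step can be read between them. The compounds shown leave open whether 1H-indazol-3-yl in place of ((furan-2-yl)methyl)carbamoyl shifts the tolerated concentration in either direction.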